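The compounds below may be only part of what the source reports. "The series", "measured", "known", "first", "only" and "open" are said of these compounds alone.

Three semicarbazone compounds sharing one core were examined in a functional assay on the whole organism with Mus musculus as the target, in the maximal electroshock model, with a stated time of 1 h; on this read-out higher numbers stand for an effect only at larger amounts of compound and lower numbers for an effect already at smaller amounts. Compound 1 `NC(=O)N/N=C/c1ccc(Oc2ccc(F)cc2F)cc1` gives 96.8 mg/kg in this assay. Compound 2 `NC(=O)N/N=C/c1ccc(Oc2ccc(F)cc2Cl)cc1` gives 13.1 mg/kg. The two differ in one place, (chloro in place of fluoro on an aromatic carbon), and the step is a 7.4-fold lower number from compound 1 to compound 2 (0.87 log units; beyond the scatter). Compound 3 `NC(=O)N/N=C/c1ccc(Sc2ccc(F)cc2)cc1` gives 12.4 mg/kg, a number within the scatter of that of compound 2 and well apart from that of compound 1; the difference between the core of compound 3 and the core of compound 1 is not broken down here.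

Compound 4 `NC(=O)N/N=C/c1ccc(Sc2ccc(Cl)cc2)cc1` has not yet been measured. It differs from compound 3 by chloro in place of fluoro on an aromatic carbon. This is the same kind of change as that from compound 1 to compound 2, but not the same: in compound 4 the chloro stands para to a large group, whereas in compound 2 it stands ortho to a large group and meta to a fluoro group. Because of a 7.4-fold lower number from compound 1 to compound 2 (0.87 log units; beyond the scatter) the expectation for compound 4 in this assay is a lower number than that of compound 3, though a smaller step is expected given the different surroundings, amounting to a 2.1-fold lower number from compound 3 to compound 4 (0.32 log units; beyond the scatter). Compound 4 is therefore estimated at 6 mg/kg in this assay, with a likely range from 2 mg/kg to 15 mg/kg.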

Compound 4, dose for half-maximal effect: 16.2 mg/kg
Compound 4: middle estimate off by 2.7-fold (0.43 log units), on the low side; measured number outside the range, above it.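

In this assay, the exchange of fluoro for chloro on an aromatic carbon did not carry over from the core of compound 1 to the core of compound 3; here the step is a 1.3-fold higher number from compound 3 to compound 4 (0.12 log units; within the scatter), which cannot be told from the scatter. The two instances of the same change disagree by more than repeated measurement would account for: the same change on two cores in this assay, a 7.4-fold lower number (0.87 log units; beyond the scatter) from compound 1 to compound 2 and a 1.3-fold higher number (0.12 log units; within the scatter) from compound 3 to compound 4, 9.7-fold (0.98 log units) apart, beyond the scatter of two such steps This shows that the large step seen on the first core cannot be taken as a general rule for the series, but it does not show what sets the two instances apart, whether the difference between the cores or the place of the exchanged atom, which in compound 4 is para to a large group, and one pair on each core is too little to separate these.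

The compounds shown leave open how a bromo, methyl, methoxy or trifluoromethyl group on the same aromatic carbon would compare with fluoro and chloro on either core. Also open, from the compounds shown here alone, is whether an amine or a carboxylic acid at that place would fit the behaviour of either core in this model.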